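Cyanomethyl to acetyl on a xanthine side chain

This account rests on a few compounds, and the source may have more. Where it says the series, first, only, none or still open, it means among the compounds named here.

Of the compounds shown here, two have been measured in an assay on Cerebral cortex for binding affinity to adenosine receptor A1 (Cavia porcellus), read by radioligand binding; a lower number here means a stronger inhibitor, a higher number a weaker inhibitor. Compound 1 `C=CCn1c(=O)c2[nH]cnc2n(CCC)c1=O` gives 1700 nM in this assay. Within the data shown here, compound 2 `CCCn1c(=O)n(C)c(=O)c2c1ncn2CCC#N` gives 88600 nM in this assay, the higher of the two numbers, so compound 2 is the weaker inhibitor of the pair; no single-point step connects it to compound 1, and the two values are simply read side by side. Compound 3 `CCCn1c(=O)n(C)c(=O)c2c1ncn2CC(C)=O` has not yet been measured. It differs from compound 2 by one change: acetyl in place of cyanomethyl on a saturated chain carbon bound to an aromatic nitrogen. The group that leaves and the group that enters are of the same size, each without a ring and each carrying one hydrogen-bond acceptor, so compound 3 is expected to stay close to compound 2, with a 1.5-fold lower number from compound 2 to compound 3 (0.17 log units; within the scatter) not expected to go beyond the usual scatter. For compound 3 the estimated value is 60000 nM, expected to lie between 15000 nM and 250000 nM.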

Compound 3, inhibition constant: 95700 nM
For compound 3 the middle estimate is 1.6-fold (0.20 log units) below the measured one; measured number inside the range.
By their numbers in this assay, from the lowest: compound 1; then compounds 2 and 3 (each within the scatter of the next).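

In this assay, acetyl in place of cyanomethyl on a saturated chain carbon bound to an aromatic nitrogen gives a 1.1-fold higher number from compound 2 to compound 3 (0.03 log units; within the scatter), so at this place the two groups cannot be told apart by this measurement. The step is the only single-change comparison among the compounds shown, and it gives this position a reading that the side-by-side values of compound 1 and compound 2 could not give. No measurement at hand accounts for the nitrile and the carbonyl reading alike. On these data alone, it remains open whether an amine, a carboxylic acid or a longer chain at this place would shift the number beyond the scatter. Also open, as far as these compounds go, is whether the same exchange would read alike on the core of compound 1.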